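The source may report more compounds than this note shows. Statements on the series, on what has been measured and on what is new or still open speak of the compounds shown alone.

Measured compounds:
Compound 1 `O=C(Nc1cccc(-c2oc3cc(-c4ccc(F)cc4)ccc3c(=O)c2O)c1)c1ccc(F)cc1` gives 5350 nM in a functional assay on HeLa cells (Homo sapiens) for antiproliferative activity, read by CCK-8 assay, with a stated time of 72 h; on this read-out higher numbers stand for weaker inhibition and lower numbers for stronger inhibition.
Compound 2 `COc1ccc(C(=O)Nc2cccc(-c3oc4cc(-c5ccc(F)cc5)ccc4c(=O)c3O)c2)cc1` gives 4820 nM in this assay.
Compound 3 `O=C(Nc1cccc(-c2oc3cc(-c4ccc(F)cc4)ccc3c(=O)c2O)c1)c1ccc(Cl)cc1` gives 3670 nM in this assay.

Compound 2 stands second highest of the three numbers. Its nearest neighbour is compound 1, with a 1.1-fold lower number from compound 1 to compound 2 (0.05 log units; within the scatter), and its furthest is compound 3, with a 1.3-fold lower number from compound 2 to compound 3 (0.12 log units; within the scatter); compound 1 and compound 3 are separated by a 1.5-fold lower number from compound 1 to compound 3 (0.16 log units; within the scatter). All three measured steps lie within the scatter, so the shared core has so far tolerated fluoro, methoxy and chloro on the outer aromatic carbon without any change that can be trusted.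

Compound 4 `COc1cccc(C(=O)Nc2cccc(-c3oc4cc(-c5ccc(F)cc5)ccc4c(=O)c3O)c2)c1` has not yet been measured. It differs from compound 2 by 3-methoxyphenyl in place of 4-methoxyphenyl on a carbonyl carbon. Among the measured compounds shown here, none of the measured steps moves a methoxy group from one place to another on that ring; they only exchange one substituent for another at a fixed place, and each of those exchanges stayed within the scatter. Nothing in the data therefore points to a step beyond the scatter in either direction for compound 4, and the estimate is set close to compound 2. Compound 4 is expected to give 4600 nM in this assay, within a range from 2000 nM to 10500 nM. This estimate amounts to an expected step of a 1.0-fold lower number from compound 2 to compound 4 (0.02 log units; within the scatter).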

Compound 4, half-maximal inhibitory concentration: 5650 nM
Estimate against measurement, compound 4: 1.2-fold (0.09 log units) below, and the stated range covers the measured number.
By their numbers in this assay, from the lowest: compounds 3, 2, 1 and 4 (each within the scatter of the next).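

In this assay, among the compounds shown here, the exchange of 4-methoxyphenyl for 3-methoxyphenyl on the carbonyl carbon gives a 1.2-fold higher number from compound 2 to compound 4 (0.07 log units; within the scatter) and is the first step to alter where a group sits on that ring, not which group sits there. The exchanges of 4-chlorophenyl and of 4-fluorophenyl for 3-methoxyphenyl at the same carbon read as a 1.5-fold higher number from compound 3 to compound 4 (0.19 log units; within the scatter) and as a 1.1-fold higher number from compound 1 to compound 4 (0.02 log units; within the scatter) and so, like the earlier steps, stay within the scatter, which means that among these four compounds neither the identity of the substituent nor this shift of the methoxy group has yet made a difference that can be trusted. No measurement is available that would bear on these results or offer an account of them.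

From the compounds shown here alone, it remains open whether an amine or a carboxylic acid on this ring, or a longer chain in place of the ring on the carbonyl carbon, would give a step beyond the scatter. The four compounds also share everything outside the group on the carbonyl carbon, so they show nothing about how the rest of the core contributes to the read-out.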